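Cyano for Methyl on a Shared Core: Clearance Outlook

The source may hold more compounds than are shown below. What is called first, only, known or untested is meant among the compounds shown, and "the series" means these compounds.

Compound 1 `COCc1cc(OC)c(-c2cccc3c(N(CC4CCOCC4)CC4CC4)c(C)nn23)c(OC)c1` was run in an in vitro ADME assay on microsomes from liver (Homo sapiens) for metabolic stability, with a stated time of 15 min (on this read-out higher numbers stand for fast clearance and lower numbers for slow clearance), where compound 1 gives 110 mL.min-1.g-1. Of the two compounds measured, compound 1 has the lowest number; the nearest is compound 2 `CCc1nn2c(-c3c(C)cc(C)cc3OC)cccc2c1N(CCCF)CC1CC1`, which in this assay gives 1410 mL.min-1.g-1, a gap beyond the usual scatter. Compound 3 `COCc1cc(OC)c(-c2cccc3c(N(CC4CCOCC4)CC4CC4)c(C#N)nn23)c(OC)c1` is compound 1 with a single change: cyano in place of methyl on an aromatic carbon. Among the compounds with values here, no measured pair shows this exact change, so the outlook rests on the value of compound 1 alone. In this assay only a small step is expected, at most a modest move toward slower clearance, close to the scatter: a 1.4-fold lower number from compound 1 to compound 3 (0.14 log units; within the scatter). Compound 3 is therefore estimated at 80 mL.min-1.g-1, most likely between 35 mL.min-1.g-1 and 180 mL.min-1.g-1.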

Compound 3, intrinsic clearance in microsomes: 1100 mL.min-1.g-1
The estimate for compound 3 lay 14-fold (1.14 log units) below the measured number; measured number outside the range, above it.
By their numbers in this assay, from the lowest: compound 1; then compounds 3 and 2 (each within the scatter of the next).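

At this aromatic carbon, next to the ring nitrogen, the shared core proves sensitive in this assay: cyano in place of methyl gives a 10-fold higher number from compound 1 to compound 3 (1.00 log units; beyond the scatter), a clear move toward fast clearance. This single pair thus shows that a small swap at this position can change the read-out beyond the scatter. Nothing shown explains why this happens.

On these data alone, it remains open whether another group here, such as a chlorine atom or a primary amide, would stay closer to compound 1. As far as these compounds go, it is also open whether cyano would act the same way with different groups elsewhere on the core.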